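The source may report more compounds than this note shows. Statements on the series, on what has been measured and on what is new or still open speak of the compounds shown alone.

Measured in a functional assay on A549 cells (Homo sapiens) for cytotoxicity, read by MTT assay, with a stated time of 72 h; on this read-out higher numbers stand for weaker inhibition and lower numbers for stronger inhibition:
compound 1 `COc1cc2c(Oc3ccc(NC(=O)N/N=C/c4ccc(F)cc4Cl)cc3F)ccnc2cc1OCCCN1CCCCC1` – 130 nM
compound 2 `COc1ccc(/C=N/NC(=O)Nc2ccc(Oc3ccnc4cc(OCCCN5CCCCC5)c(OC)cc34)c(F)c2)c(OC)c1` – 1400 nM
compound 3 `COc1cc2c(Oc3ccc(NC(=O)N/N=C/c4ccc(N(C)C)cc4)cc3F)ccnc2cc1OCCCN1CCCCC1` – "not determined" (no result reported), no number reported

Compound 1 holds the lower of the two numbers that were determined; the nearest entry is compound 2, and the step of an 11-fold higher number from compound 1 to compound 2 (1.03 log units; beyond the scatter) lies beyond the scatter. That step exchanges the aryl group on the carbon with a double bond to nitrogen and leaves the rest of the shared core untouched. Compound 3, with a dimethylamino-bearing aryl at the same carbon, adds no number to the comparison.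

Compound 4 `COc1cc2c(Oc3ccc(NC(=O)N/N=C/c4ccc(F)cc4Cl)cc3F)ccnc2cc1OCCCN1CCC(C)CC1` differs from compound 1 in one place only: methyl in place of hydrogen on a saturated ring carbon. Within the data shown here, none of the measured steps touches this part of the molecule. Among the measured compounds shown here, the single step that is known, the aryl exchange, was large, but it bears on the hydrazone end and not on the saturated ring; it gives no guide to the effect of a methyl there. With nothing in the series that speaks to this change, compound 4 is expected to sit within the scatter of compound 1, i.e. a step of a 1.1-fold higher number from compound 1 to compound 4 (0.03 log units; within the scatter). Compound 4 is therefore estimated at 140 nM, with a range of 50 nM to 400 nM.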

Compound 4, half-maximal inhibitory concentration: 190 nM
Compound 4: middle estimate off by 1.4-fold (0.13 log units), on the low side; the measured number falls inside the stated range.
By their numbers in this assay, from the lowest: compounds 1 and 4 (each within the scatter of the next); then compound 2.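

Piperidin-1-yl to 4-methylpiperidin-1-yl is the first change in the series that touches the saturated ring, and in this assay it gives a 1.5-fold higher number from compound 1 to compound 4 (0.16 log units; within the scatter) on this read-out. Among these compounds, the added methyl, three ring bonds from the ring nitrogen, therefore leaves compound 4 and compound 1 indistinguishable, whereas the aryl exchange at the hydrazone end gives an 11-fold higher number from compound 1 to compound 2 (1.03 log units; beyond the scatter) and remains the only step beyond the scatter. The data shown offer no measurement that would account for either outcome.

Open, on these data alone, is whether this ring carbon accepts more than a single methyl: a hydroxyl group, a primary amine, a carboxylic acid or a longer chain there could behave differently, as could morpholin-4-yl in place of the whole piperidin-1-yl group. Also open, as far as these compounds go, is whether the result for 4-methylpiperidin-1-yl carries over to other aryl groups at the hydrazone end, such as the 2,4-dimethoxyphenyl of compound 2, since the methyl has been seen only alongside 2-chloro-4-fluorophenyl.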